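The compounds below may be only part of what the source reports. "The series", "measured", "known", "first", "only" and "open" are said of these compounds alone.

Compound 1 `COC(=O)CO/N=C(\C)c1ccc(Cl)cc1`: 24 mg/kg
Compound 2 `C/C(=N\OCCC(=O)O)c1ccc(Cl)cc1`: 80 mg/kg
Compound 3 `CNC(=O)CO/N=C(\C)c1ccc(Cl)cc1`: 70 mg/kg

These values come from a functional assay on the whole organism for inhibition, with Rattus norvegicus as the target, read by paw edema, with stated times of 1 h and 3 h; on this read-out higher numbers stand for an effect only at larger amounts of compound and lower numbers for an effect already at smaller amounts. Compound 3 has the second highest of the three numbers, level with compound 2 within the scatter, as a 1.1-fold lower number from compound 2 to compound 3 (0.06 log units; within the scatter) shows. Compound 4 `C/C(=N\OCC(=O)N(C)C)c1ccc(Cl)cc1` carries methyl in place of hydrogen on an amide-type nitrogen. For the measured compounds named here, no measured step makes this exact change. The closest is a 2.9-fold higher number from compound 1 to compound 3 (0.46 log units; beyond the scatter), a modest change at the same end of the molecule, so only a small shift is expected. The expected move is a 1.4-fold lower number from compound 3 to compound 4 (0.15 log units; within the scatter), slightly downward and not beyond the scatter. For compound 4 the estimated value is 50 mg/kg, with an expected range of 22 mg/kg to 110 mg/kg.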

Compound 4, dose for half-maximal effect: 120 mg/kg
For compound 4 the middle estimate is 2.4-fold (0.38 log units) below the measured one; the measured number lies above the stated range.
By their numbers in this assay, from the lowest: compound 1; then compounds 3, 2 and 4 (each within the scatter of the next).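

In this assay, methyl in place of hydrogen on the amide-type nitrogen gives a 1.7-fold higher number from compound 3 to compound 4 (0.23 log units; within the scatter) and so leaves no readable change at this position. For the compounds shown here, the dimethylcarbamoyl compound also stays level with the carboxymethyl compound, at a 1.5-fold higher number from compound 2 to compound 4 (0.18 log units; within the scatter), while dimethylamino in place of methoxy on the carbonyl carbon gives a 5.0-fold higher number from compound 1 to compound 4 (0.70 log units; beyond the scatter) and is the only new step beyond the scatter. Nothing measured here explains these numbers.

From the compounds shown here alone, whether a longer chain such as ethyl on that nitrogen, or a ring amine such as morpholine in place of dimethylamino, would keep the number level remains open.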